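Pyridin-3-yl in place of cyclohexyl on the side chain

The compounds below may be only part of what the source reports. "The series", "measured", "known", "first", "only" and "open" are said of these compounds alone.

Measured compounds:
compound 1 `O[C@@H](c1ccccc1)[C@H]1CO[C@H](c2ccccc2)[C@@H](C/C=C/C2CCCCC2)C1`: 6260 nM
compound 3 `O=[N+]([O-])c1ccccc1/C=C/C[C@H]1C[C@@H]([C@@H](O)c2ccccc2)CO[C@@H]1c1ccccc1`: 7250 nM
compound 2 `COc1ccc(/C=C/C[C@@H]2C[C@H]([C@H](O)c3ccc(OC)c(OC)c3)CO[C@H]2c2ccc(OC)c(OC)c2)cc1OC`: "not determined" (no result reported)

In a functional assay on HL-60 cells (Homo sapiens) for cytotoxicity, read by WST assay, with a stated time of 48 h (a higher number here means a weaker inhibitor, a lower number a stronger inhibitor), compound 1 gives 6260 nM, the lowest of the two numbers reported. Compound 3 gives 7250 nM; the single-point step is a 1.2-fold higher number from compound 1 to compound 3 (0.06 log units; within the scatter). For compound 2 no number is reported.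

Compound 4 `O[C@@H](c1ccccc1)[C@H]1CO[C@H](c2ccccc2)[C@@H](C/C=C/c2cccnc2)C1` differs from compound 1 in one place: pyridin-3-yl in place of cyclohexyl on a double-bonded chain carbon bound to a double-bonded chain carbon. Among the compounds with values here, the one measured step that bears on this is a 1.2-fold higher number from compound 1 to compound 3 (0.06 log units; within the scatter), in which a different six-membered aromatic ring took the place of the same cyclohexyl at the same place and left the number within the scatter. On that basis no shift beyond the scatter is expected, with a 1.1-fold higher number from compound 1 to compound 4 (0.05 log units; within the scatter). Compound 4 is therefore estimated at 7000 nM, within 3000 nM to 16000 nM.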

Compound 4, half-maximal inhibitory concentration: > 100000 nM
Compound 4: a limit, no number; the forecaster's own chance of this, stated with the estimate: 10%; at least 14-fold (1.15 log units) between middle value and limit.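

In this assay, pyridin-3-yl on this chain gives an at least 15-fold higher number from compound 1 to compound 4 (1.20 log units; beyond the scatter), and in place of 2-nitrophenyl it gives an at least 13-fold higher number from compound 3 to compound 4 (1.13 log units; beyond the scatter). A six-membered aromatic ring alone does not decide the outcome at this place, since compound 3 carries one and stays within the scatter of compound 1, while compound 4 does not. The result for compound 4 is a limit of the assay, not a number: the limit of > 100000 nM in this assay, at which 1 of the 4 values shown sits.

From the compounds shown here alone, the true size of both steps stays open. So does whether unsubstituted phenyl or pyridin-4-yl at this place would read like compound 1 or like compound 4.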